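Swapping a Triazole Ester for an Isoxazole Ester

The compounds below may be only part of what the source reports. "The series", "measured", "known", "first", "only" and "open" are said of these compounds alone.

Compound 1 `CCOC(=O)c1nnn(-c2cccc(NC(=O)c3ccc(/C=C/C(=O)c4ccc(Cl)cc4)cc3)c2)c1C` carries a 4-(ethoxycarbonyl)-5-methyl-1H-1,2,3-triazol-1-yl group on the shared core. In an ADME assay on Vero cells (Chlorocebus sabaeus) for cytotoxicity, read by MTT assay, with a stated time of 72 h (on this read-out higher numbers stand for lower toxicity in this test and lower numbers for higher toxicity in this test), compound 1 gives "not determined" (no result reported), so its place on the scale is open. Two relatives provide the only setting. Compound 2 `COC(=O)c1cc(-c2cccc(NC(=O)c3ccc(/C=C/C(=O)c4ccc(F)cc4F)cc3)c2)on1` in this assay gives > 40 ug/mL, a limit of the assay rather than a number. Compound 3 `COC(=O)c1cc(-c2cccc(NC(=O)c3ccc(/C=C/C(=O)c4ccc(OC)c(OC)c4)cc3)c2)on1` in this assay gives > 50 ug/mL, also a limit. The step that the two limits leave unreadable from compound 2 to compound 3 therefore cannot be sized, and it concerns the aryl group on the carbonyl carbon, not the ring at issue here. Compound 4 `CCOC(=O)c1cc(-c2cccc(NC(=O)c3ccc(/C=C/C(=O)c4ccc(Cl)cc4)cc3)c2)on1` differs from compound 1 by 3-(ethoxycarbonyl)-1,2-oxazol-5-yl in place of 4-(ethoxycarbonyl)-5-methyl-1H-1,2,3-triazol-1-yl on an aromatic carbon. Going by the values given here, no measured step follows this change, and the only two values seen, the limit of > 40 ug/mL in this assay, at which 1 of the 3 values shown sits, and (the limit of > 50 ug/mL in this assay, at which 1 of the 3 values shown sits), are both limits, so no direction or size of step can be drawn from them. On that thin footing compound 4 is expected to give about 50 ug/mL in this assay, quite possibly again as a limit, within a range from 20 ug/mL to 120 ug/mL.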

Compound 4, half-maximal cytotoxic concentration: > 80 ug/mL
Compound 4: a limit, no number; the forecaster's own chance of this, stated with the estimate: 70%; middle value at least 1.6-fold (0.20 log units) from the limit.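

In this assay compound 4 gives > 80 ug/mL, which is a limit of the assay and not a number. Compound 1 gives "not determined" (no result reported), so no step can be read between compound 1 and compound 4. The compounds shown leave open whether 3-(ethoxycarbonyl)-1,2-oxazol-5-yl in place of 4-(ethoxycarbonyl)-5-methyl-1H-1,2,3-triazol-1-yl changes the result in this assay at all.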